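The source may hold more compounds than are shown below. What is called first, only, known or untested is meant among the compounds shown, and "the series" means these compounds.

In a functional assay on FM3A cells (Mus musculus) for antiproliferative activity, with a stated time of 48 h (a lower number here means a stronger inhibitor, a higher number a weaker inhibitor), compound 1 `C=C(Br)C(=O)Nc1ccc(/C=C/C(=O)c2cccc(OC)c2)cc1` gives 2700 nM and compound 2 `Nc1ccc(/C=C/C(=O)c2ccccc2)cc1` gives 146000 nM as the higher of the two numbers, a gap beyond the scatter. Within the data shown here, compound 3 `COc1cccc(C(=O)/C=C/c2ccc(N)cc2)c1` differs from compound 2 by methoxy in place of hydrogen on an aromatic carbon as the only change: methoxy in place of hydrogen on an aromatic carbon, meta to a large group. Among the measured compounds shown here, compound 1 also carries methoxy but differs elsewhere too, so no measured step isolates this change. A small move toward a lower number in this assay is expected, perhaps none beyond the scatter, with a 2.1-fold lower number from compound 2 to compound 3 (0.32 log units; beyond the scatter) as the estimated step. The estimated value for compound 3 is 70000 nM within an expected range of 20000 nM to 200000 nM for this compound.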

Compound 3, half-maximal inhibitory concentration: 43000 nM
Beside the measured number, compound 3's estimate is 1.6-fold (0.21 log units) above it; low and high end bracket the measured number.
By their numbers in this assay, from the lowest: compound 1; then compound 3; then compound 2.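

In this assay methoxy in place of hydrogen on an aromatic carbon, meta to a large group, gives a 3.4-fold lower number from compound 2 to compound 3 (0.53 log units; beyond the scatter) as a modest step. Hydrogen in place of (1-bromoethenyl)carbonyl on a nitrogen on an aromatic ring gives a 16-fold higher number from compound 1 to compound 3 (1.20 log units; beyond the scatter) as a large step, so with methoxy present in both compounds the group on that nitrogen accounts for the bigger difference. No measured evidence bears on the origin of either step. 

As far as these compounds go, it remains open whether a hydroxyl or a fluorine at the methoxy position would give a similar step. From the compounds shown here alone, it also remains open whether a plain acetyl on the nitrogen would match the (1-bromoethenyl)carbonyl.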